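The source may hold more compounds than are shown below. What is called first, only, known or untested is meant among the compounds shown, and "the series" means these compounds.

Compound 1 `FC(F)(F)c1cccc(NC(=S)Nc2ccc(I)cc2)c1` gives 9500 nM
Compound 2 `N#Cc1ccc(NC(=S)Nc2cccc(C(F)(F)F)c2)cc1` gives 10000 nM
Compound 3 `Fc1ccc(NC(=S)Nc2cccc(C(F)(F)F)c2)cc1Cl` gives 11000 nM

All three compounds were tested in an ADME assay on MDBK cells (Bos taurus) for cytotoxicity, read by MTT assay, with a stated time of 96 h (on this read-out lower numbers stand for higher toxicity in this test and higher numbers for lower toxicity in this test), and their numbers lie within the usual scatter of one another. Compound 3 therefore stands level with compound 1 and compound 2. Compound 4 `Cc1ccc(NC(=S)Nc2cccc(C(F)(F)F)c2)cc1Cl` carries methyl in place of fluoro on an aromatic carbon, ortho to a chloro group methyl in place of fluoro on an aromatic carbon and has not yet been measured. Among the compounds with values here, only one measured step offers any guide, a different swap of cyano in place of iodo on an aromatic carbon. That step, a 1.1-fold higher number from compound 1 to compound 2 (0.02 log units; within the scatter), is small, so it is only indirect evidence. No step beyond the scatter is expected in this assay here. The expected step is a 1.1-fold lower number from compound 3 to compound 4 (0.04 log units; within the scatter). For compound 4 the estimated value is 10000 nM, with an expected range from 5000 nM to 21000 nM.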

Compound 4, half-maximal cytotoxic concentration: 10000 nM
Estimate against measurement, compound 4: no gap at the digits printed; low and high end bracket the measured number.
By their numbers in this assay, from the lowest: compounds 1, 2, 4 and 3 (each within the scatter of the next).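

On the aromatic carbon ortho to a chloro group, methyl in place of fluoro gives a 1.1-fold lower number from compound 3 to compound 4 (0.04 log units; within the scatter) in this assay. Here, para to a large group, the two small groups therefore cannot be told apart in this cytotoxicity test, and this comparison is the only one at this position. From the compounds shown here alone, whether an amine, a carboxylic acid or a longer chain at this place would give a step beyond the scatter stays open. There is also no measured evidence that bears on why compound 3 and compound 4 sit so close.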